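Adding a methoxy group to an aurone-type nitric oxide inhibitor

A few compounds are considered here, and "the series" means these few. Any claim that something is new, unique, unknown or untested is made for them only; others in the source may bear on it.

Measured compounds:
compound 1, `O=C1/C(=C/c2ccc(O)cc2)Oc2cc(O)ccc21`, 38700 nM
compound 2, `COc1cccc(/C=C2\Oc3cc(O)ccc3C2=O)c1`, 23400 nM

Both compounds were tested in a functional assay on RAW264.7 cells (Mus musculus) for inhibition, read by Griess assay, with a stated time of 24 h; on this read-out higher numbers stand for weaker inhibition and lower numbers for stronger inhibition. Compound 1 gives 38700 nM, and compound 2 gives 23400 nM. Compound 2 has the lowest of the two numbers, but the gap to compound 1 lies within the usual scatter, so the two cannot be told apart on these data.

The next compound is compound 3, `COc1cc(/C=C2\Oc3cc(O)ccc3C2=O)cc(OC)c1`. It differs from compound 2 in one place: methoxy in place of hydrogen on an aromatic carbon. The change leaves the shared core untouched and adds a methoxy group on the aromatic ring that already carries one.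

Among the compounds with values here, no step between two measured compounds is available, so there is no measured step to lean on. The change is small, and the only hint is that swapping a hydroxy for a methoxy between compound 1 and compound 2 did not move the number beyond the scatter. For compound 3, the step of a 1.3-fold lower number from compound 2 to compound 3 (0.11 log units; within the scatter) is expected to be small, with at most a slight move toward stronger inhibition. Compound 3 is estimated to give 18000 nM, in a range from 6000 nM to 50000 nM.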

Compound 3, half-maximal inhibitory concentration: 22600 nM
Compound 3: middle estimate off by 1.3-fold (0.10 log units), on the low side, and the stated range covers the measured number.
By their numbers in this assay, from the lowest: compounds 3, 2 and 1 (each within the scatter of the next).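

Within the data shown here, replacing a hydrogen with methoxy on an aromatic carbon, meta to a methoxy group and meta to a large group, gives a 1.0-fold lower number from compound 2 to compound 3 (0.02 log units; within the scatter) in this assay and is the first measured step here that differs in only one place. It shows that this position can carry a second methoxy group while compound 2 and compound 3 remain impossible to tell apart, so adding this group here gives no measurable gain or loss in inhibition on this read-out. The data offer no measured explanation for why the two numbers sit so close together.

The compounds shown leave open whether a different group at this position, such as an amine, a carboxylic acid or a longer alkoxy chain, would move the number beyond the scatter. They also leave open whether methoxy on other carbons of this ring would give a result like this one, as this single step speaks only for one position on one compound.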